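A few compounds are considered here, and "the series" means these few. Any claim that something is new, unique, unknown or untested is made for them only; others in the source may bear on it.

Compound 3 `CCCC(CO)NCc1nc2c(OCC3CCCCC3)cccc2[nH]1` gives the highest number of the three measured compounds in an assay on cells for inhibition of interleukin-5 receptor subunit alpha (Mus musculus), read by WST assay, with a stated time of 48 h, tested at 30 uM, in the presence of a further agent that is not named here (on this read-out lower numbers stand for less inhibition and higher numbers for more inhibition at the one concentration tested (going by the name of the read-out)), with 73.3%. Compound 1 `OCCCNCc1nc2c(OCC3CCCCC3)cccc2[nH]1` gives 52.7% and compound 2 `OCCCCNCc1nc2c(OCC3CCCCC3)cccc2[nH]1` gives 44.3%; the change from compound 1 to compound 2 was a number 8.4 percentage points lower from compound 1 to compound 2 (within the scatter). The steps to compound 3 were a number 20.6 percentage points higher from compound 1 to compound 3 (beyond the scatter) and a number 29 percentage points higher from compound 2 to compound 3 (beyond the scatter), both modest gains when a branched chain carrying a hydroxymethyl replaced a straight hydroxyalkyl chain.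

Compound 4 `c1ccc(CNCc2nc3c(OCC4CCCCC4)cccc3[nH]2)cc1` differs from compound 3 by benzyl in place of 1-(hydroxymethyl)butyl on an amine nitrogen. For the measured compounds named here, no measured step removes the hydroxyl and adds an aromatic ring, so the relevant steps only show that the branched hydroxyl-bearing chain helped. Compound 4 is therefore expected to fall back, with an estimated step of a number 23.3 percentage points lower from compound 3 to compound 4 (beyond the scatter) in this assay. The estimate for compound 4 is 50%, within a range from 25% to 75%.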

Compound 4, a percentage reported as inhibition, at one concentration (the size of the read-out at that concentration, not a potency): 49.3%
Compound 4: middle estimate off by 0.7 percentage points, on the high side, within the range that was stated.
By their numbers in this assay, from the lowest: compounds 2, 4 and 1 (each within the scatter of the next); then compound 3.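

Replacing the branched chain on the amine nitrogen with benzyl gives a number 24 percentage points lower from compound 3 to compound 4 (beyond the scatter) in this assay and so loses the gain seen with 1-(hydroxymethyl)butyl. The steps of a number 5 percentage points higher from compound 2 to compound 4 (within the scatter) and a number 3.4 percentage points lower from compound 1 to compound 4 (within the scatter) show that benzyl, with an aromatic ring and no hydroxyl, stays level with the straight hydroxyalkyl chains, so among these compounds only the branched chain stands apart. Nothing here accounts for these differences.

Still open, going by these compounds, is whether the branching or the hydroxyl matters in compound 3, a question that a 1-methylbutyl group would address. On these data alone, it is also open whether a benzyl group carrying a hydroxymethyl would recover the higher number.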